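Replacing the Amide Side Chain: What Compound 4 Might Show

This account rests on a few compounds, and the source may have more. Where it says the series, first, only, none or still open, it means among the compounds named here.

Of the compounds shown here, three sharing one core have been measured in an assay on membranes from CHO cells for displacement of a labelled ligand from adenosine receptor A1 (Homo sapiens), read by scintillation counting, with a stated time of 60 min, tested at 1 uM; on this read-out lower numbers stand for less inhibition and higher numbers for more inhibition at the one concentration tested (going by the name of the read-out). Compound 1 `CC1=C(C(=O)NC(C)C)C(c2ccco2)NC(=O)N1` gives 3%, compound 2 `CC1=C(C(=O)NC(C)C)C(c2cccs2)NC(=O)N1` gives 2%, and compound 3 `CC1=C(C(=O)NC(C)C)C(c2ccsc2)NC(=O)N1` gives 8%. These three differ only in the aromatic group on a saturated ring carbon, and the steps between them are all small: a number 1 percentage points lower from compound 1 to compound 2 (within the scatter), a number 5 percentage points higher from compound 1 to compound 3 (within the scatter) and a number 6 percentage points higher from compound 2 to compound 3 (within the scatter). Compound 3 has the highest of the three numbers, but its gaps to compound 1 and compound 2 lie within the scatter, so all three sit together at low inhibition.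

Compound 4 `CC1=C(c2ncc(C)o2)C(c2ccsc2)NC(=O)N1` has not yet been measured. It differs from compound 3 in one place: 5-methyl-1,3-oxazol-2-yl in place of isopropylcarbamoyl on a double-bonded ring carbon. The group that leaves is an isopropylcarbamoyl carrying one hydrogen-bond donor; the group that enters is a 5-methyl-1,3-oxazol-2-yl, an aromatic ring with no donor. Within the data shown here, none of the measured steps touches this position, so they give no direct guide to its effect; they show only that this core has stayed at low inhibition across three aromatic groups. Among the measured compounds shown here, with no measured step bearing on the change, the expectation for compound 4 in this assay rests on that low starting point, and the step expected is no change at the digits printed from compound 3 to compound 4 (within the scatter). Compound 4 is therefore estimated at 8%, within a range from 0% to 25%.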

Compound 4, a percentage reported as inhibition, at one concentration (the size of the read-out at that concentration, not a potency): 34%
Compound 4: middle estimate off by 26 percentage points, on the low side; the measured number lies above the stated range.
By their numbers in this assay, from the lowest: compounds 2, 1 and 3 (each within the scatter of the next); then compound 4.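

In this assay, among these compounds, the swap at this double-bonded ring carbon gives a number 26 percentage points higher from compound 3 to compound 4 (beyond the scatter), so this position can move the number beyond the scatter, which no change of the aromatic group on the saturated ring carbon did among the earlier compounds. The isopropylcarbamoyl and the 5-methyl-1,3-oxazol-2-yl have the same heavy-atom count, so the change lies not in that count but in the arrival of a five-membered aromatic ring, the loss of the hydrogen-bond donor and a different acceptor count, and this single step cannot separate those differences. Nothing measured here explains the rise.

The compounds shown leave open whether the rise is particular to the 5-methyl-1,3-oxazol-2-yl or would also appear with an unsubstituted oxazole, a phenyl ring or an ethyl ester on the same carbon. Also open, from the compounds shown here alone, is whether the 5-methyl-1,3-oxazol-2-yl would give a similar rise alongside furan-2-yl or thiophen-2-yl, and how potent compound 4 is, since a reading at one concentration gives the size of the inhibition there and not a potency.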